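The source may report more compounds than this note shows. Statements on the series, on what has been measured and on what is new or still open speak of the compounds shown alone.

Measured so far in a functional assay on HCT-116 cells (Homo sapiens) for cytotoxicity, read by resazurin assay, with a stated time of 48 h; on this read-out lower numbers stand for an effect already at smaller amounts and higher numbers for an effect only at larger amounts of compound
- compound 1 `COc1ccc(S(=O)(=O)Nc2ccc3oc(-c4ccc(NC(=O)c5cccc(C)c5[N+](=O)[O-])cc4)nc3c2)cc1` gives 4400 nM
- compound 2 `COc1ccc(S(=O)(=O)Nc2ccc3oc(-c4ccc(NS(=O)(=O)c5cc(Br)ccc5OC)cc4)nc3c2)cc1` gives 12000 nM

Of these two values, the higher belongs to compound 2 (12000 nM). The next compound to consider is compound 3 `COc1ccc(S(=O)(=O)Nc2ccc3oc(-c4ccc(NC(=O)C5CCN(C(C)=O)CC5)cc4)nc3c2)cc1`, which differs from compound 2 as follows: (1-acetylpiperidin-4-yl)carbonyl in place of (5-bromo-2-methoxyphenyl)sulfonyl on a nitrogen on an aromatic ring. In words, (1-acetylpiperidin-4-yl)carbonyl stands in place of (5-bromo-2-methoxyphenyl)sulfonyl on a nitrogen on an aromatic ring.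

For the measured compounds named here, only one measured step bears on this change: a 2.7-fold higher number from compound 1 to compound 2 (0.44 log units; beyond the scatter). That modest step replaced a carbonyl group with a sulfonyl group at the same place. Compound 3 returns to a carbonyl group there, but with a non-aromatic ring, so this single step is a weak guide. In this assay a small shift to a lower number is expected, possibly not beyond the scatter. The expected change is small (a 1.7-fold lower number from compound 2 to compound 3 (0.23 log units; within the scatter)). The estimated value for compound 3 is 7000 nM (expected range 2200 nM to 25000 nM).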

Compound 3, half-maximal effective concentration: 15000 nM
The estimate for compound 3 lay 2.1-fold (0.33 log units) below the measured number; measured number inside the range.
By their numbers in this assay, from the lowest: compound 1; then compounds 2 and 3 (each within the scatter of the next).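

In this assay, (1-acetylpiperidin-4-yl)carbonyl in place of (5-bromo-2-methoxyphenyl)sulfonyl gives a 1.3-fold higher number from compound 2 to compound 3 (0.10 log units; within the scatter), so on this nitrogen the two groups cannot be told apart, although one is a sulfonyl with an aromatic ring and the other a carbonyl with a non-aromatic ring. With the carbonyl kept, 1-acetylpiperidin-4-yl in place of 3-methyl-2-nitrophenyl gives a 3.4-fold higher number from compound 1 to compound 3 (0.53 log units; beyond the scatter), which shows that the carbonyl alone does not secure the lower number of compound 1 and that the group on the carbonyl carbon counts. No measurement at hand accounts for either step.

As far as these compounds go, it remains open whether the nitro or the methyl group of 3-methyl-2-nitrophenyl carries the difference. Also open, from the compounds shown here alone, is how a free amine in the piperidine ring, or a carboxylic acid on the carbonyl carbon, would read.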